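Urea aryl swap: from 2-(trifluoromethyl)phenyl to 3,4-difluorophenyl

A few compounds are considered here, and "the series" means these few. Any claim that something is new, unique, unknown or untested is made for them only; others in the source may bear on it.

Of the compounds shown here, three sharing one core have been measured in a functional assay on NCI-H460 cells (Homo sapiens) for antiproliferative activity, read by MTT assay, with a stated time of 72 h; a higher number here means a weaker inhibitor, a lower number a stronger inhibitor. Compound 1 `CN(C)CCCn1cnnc1-c1cc(Oc2ccc(NC(=O)Nc3ccc(Cl)c(C(F)(F)F)c3)cc2F)ccn1` gives 1680 nM, and compound 2 `CN(C)CCCn1cnnc1-c1cc(Oc2ccc(NC(=O)Nc3cccc(C(F)(F)F)c3)cc2F)ccn1` gives 1790 nM; the step of a 1.1-fold higher number from compound 1 to compound 2 (0.03 log units; within the scatter) lies within the scatter. Compound 3 `CN(C)CCCn1cnnc1-c1cc(Oc2ccc(NC(=O)Nc3ccccc3C(F)(F)F)cc2F)ccn1` gives 10900 nM, the highest of the three numbers, standing apart from both others by a 6.5-fold higher number from compound 1 to compound 3 (0.81 log units; beyond the scatter) and a 6.1-fold higher number from compound 2 to compound 3 (0.78 log units; beyond the scatter).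

Compound 4 `CN(C)CCCn1cnnc1-c1cc(Oc2ccc(NC(=O)Nc3ccc(F)c(F)c3)cc2F)ccn1` has not yet been measured in this assay. It differs from compound 3 by 3,4-difluorophenyl in place of 2-(trifluoromethyl)phenyl on an amide-type nitrogen. The two steps that bear on this change are those that led into compound 3: a 6.5-fold higher number from compound 1 to compound 3 (0.81 log units; beyond the scatter) and a 6.1-fold higher number from compound 2 to compound 3 (0.78 log units; beyond the scatter), both modest rises when the 2-(trifluoromethyl)phenyl group replaced a phenyl carrying substituents in the 3 and 4 positions. Compound 4 returns to a phenyl substituted in the 3 and 4 positions, though with fluorine in place of the larger groups of compound 1 and compound 2, so the change is expected to run in the opposite direction, bringing a lower number, yet perhaps not the full distance back. For compound 4 the estimated step in this assay is a 3.6-fold lower number from compound 3 to compound 4 (0.56 log units; beyond the scatter). Compound 4 is therefore expected to give about 3000 nM, with a likely range from 1200 nM to 8000 nM.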

Compound 4, half-maximal inhibitory concentration: 1080 nM
Compound 4: the middle estimate sits 2.8-fold (0.44 log units) above what was measured; measured number below the stated range.
By their numbers in this assay, from the lowest: compounds 4, 1 and 2 (each within the scatter of the next); then compound 3.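

In this assay, going by these compounds alone, the 3,4-difluorophenyl group on the amide-type nitrogen gives a 10-fold lower number from compound 3 to compound 4 (1.00 log units; beyond the scatter), the first step that leads away from the 2-(trifluoromethyl)phenyl compound to a group that carries no trifluoromethyl at all. The earlier compounds shown here all carried a trifluoromethyl group, yet a 1.7-fold lower number from compound 2 to compound 4 (0.22 log units; within the scatter) and a 1.6-fold lower number from compound 1 to compound 4 (0.19 log units; within the scatter) both lie within the scatter, so among compound 1, compound 2 and compound 4 the presence of trifluoromethyl or chloro makes no readable difference, and compound 3 alone stands apart from the other three. Nothing measured alongside these numbers accounts for this result.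

What the compounds shown leave open is how an unsubstituted phenyl, a 2-fluorophenyl or a 3,4-dimethoxyphenyl group would read on the same amide-type nitrogen, and so whether the higher number of compound 3 goes with the 2-substitution itself or with trifluoromethyl in particular. They also leave open whether the level shared by compound 1, compound 2 and compound 4 would hold with a morpholine in place of the dimethylamino group of the shared core.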